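The source may report more compounds than this note shows. Statements on the series, on what has been measured and on what is new or still open speak of the compounds shown alone.

In an ADME assay on microsomes from liver (Mus musculus) for metabolic stability, read by HPLC, with a stated time of 4 h (on this read-out lower numbers stand for slow clearance and higher numbers for fast clearance), compound 1 `CN(C)c1ccc2cc(-c3ccccc3)c(N)nc2c1` gives > 500 mL/min/kg as a limit of the assay and not a number. Compound 2 `CN(C)c1ccc2cc(-c3ccccc3F)c(N)nc2c1` gives > 500 mL/min/kg in the same way, again a limit and not a number. Where compound 2 stands is therefore known only as the limit of > 500 mL/min/kg in this assay, at which 2 of the 2 values shown sit, and nothing finer. Compound 3 `CN(C)c1ccc2cc(-c3ccccc3Cl)c(N)nc2c1` carries chloro in place of fluoro on an aromatic carbon, ortho to a large group, and the difference reads chloro in place of fluoro on an aromatic carbon in full. Going by the values given here, the one measured step that bears on this, fluoro in place of hydrogen, is a step that the two limits leave unreadable from compound 1 to compound 2 and so offers no size to carry over. No shift beyond the scatter can be argued from it, and the estimated step is a step that the limit leaves unreadable from compound 2 to compound 3 with no firm direction. Compound 3 is expected at 600 mL/min/kg with an estimated range from 300 mL/min/kg to 1200 mL/min/kg and may well come back as a limit again.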

Compound 3, clearance: 420 mL/min/kg
For compound 3 the middle estimate is 1.4-fold (0.15 log units) above the measured one; the measured number falls inside the stated range.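

The change from 2-fluorophenyl to 2-chlorophenyl yields the only reading shown that is a number and not a limit, and the step reads an at least 1.1-fold lower number from compound 2 to compound 3 (0.07 log units; that floor lies within the scatter). Chloro in place of hydrogen on the same aromatic carbon gives an at least 1.1-fold lower number from compound 1 to compound 3 (0.07 log units; that floor lies within the scatter). Both steps are floors, so neither shows how large the true difference is, but compound 3 gives this place a measured reference while the other two compounds remain at a limit of the assay: the limit of > 500 mL/min/kg in this assay, at which 2 of the 3 values shown sit.

The compounds shown leave open whether the result is particular to chloro or would also appear with a different group at this place, such as methoxy, a nitrile or trifluoromethyl. They also leave open how far a number in this assay could fall with any such group on the shared core.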